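Acetoxymethyl on the carbonyl carbon of compound 3

The compounds below may be only part of what the source reports. "The series", "measured", "known", "first", "only" and "open" are said of these compounds alone.

- compound 1 `COc1cc(OC)c(C2OC(c3ccc(N(C)C)cc3)=NN2C(C)=O)c(OC)c1` in a functional assay on NCI-H460 cells (Homo sapiens) (a higher number here means that more compound is needed for the effect, a lower number that less compound is needed), gives 40 uM
- compound 2 `COc1ccc(C2OC(c3ccc(N(C)C)cc3)=NN2C(C)=O)cc1OC` in this assay gives 5.1 uM
- compound 3 `COc1cc(C2OC(c3ccc(N(C)C)cc3)=NN2C=O)cc(OC)c1OC` in this assay gives 0.12 uM

Compound 3 holds the lowest number of the three, and compound 2 and compound 1 both lie above it by more than the scatter. The next compound is compound 4 `COc1cc(C2OC(c3ccc(N(C)C)cc3)=NN2C(=O)COC(C)=O)cc(OC)c1OC`, which carries acetoxymethyl in place of hydrogen on a carbonyl carbon, so that formyl becomes (acetoxymethyl)carbonyl. For the measured compounds named here, no measured pair isolates this change. Compound 2 at 5.1 uM and compound 1 at 40 uM also have something other than hydrogen on that carbonyl carbon, but they differ from compound 3 elsewhere too, so they give only a weak hint of a rise. An estimated step of a 5.0-fold higher number from compound 3 to compound 4 (0.70 log units; beyond the scatter) is expected in this assay, toward a higher number and beyond the scatter. The estimated value for compound 4 is 0.6 uM (expected range 0.08 uM to 5 uM).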

Compound 4, concentration for half-maximal effect: 0.072 uM
Compound 4: middle estimate off by 8.3-fold (0.92 log units), on the high side; measured number outside the range, below it.
By their numbers in this assay, from the lowest: compounds 4 and 3 (each within the scatter of the next); then compound 2; then compound 1.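

In this assay the exchange of hydrogen for acetoxymethyl on the carbonyl carbon gives a 1.7-fold lower number from compound 3 to compound 4 (0.22 log units; within the scatter) and so leaves compound 3 and compound 4 indistinguishable. For the compounds shown here, this is the first direct reading at this place, and it shows that a carbonyl carbon whose other neighbour is an amide-type nitrogen in a ring can carry this much larger, branched-off ester group without a rise beyond the scatter, a result the earlier compounds, which differ elsewhere too, could only hint at the other way. No measurement here accounts for this tolerance.

Open, on these data alone, is how far this tolerance extends, for instance to hydroxymethyl, aminomethyl, a carboxylic acid or a longer alkyl chain on the same carbonyl carbon. Also open, as far as these compounds go, is whether acetyl at this place, on the core of compound 3, would read the same in this cell assay.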